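Methyl in place of trifluoromethyl, a second instance

The source may report more compounds than this note shows. Statements on the series, on what has been measured and on what is new or still open speak of the compounds shown alone.

Measured compounds:
compound 1 `NC(=O)c1c(NC(=O)c2ccccc2Cl)sc2c1CCN(C(=S)Nc1ccccc1C(F)(F)F)C2` — 26700 nM
compound 3 `NC(=O)c1c(NC(=O)c2ccc(C(F)(F)F)cc2)sc2c1CCN(C(=S)Nc1ccccc1Cl)C2` — 44000 nM

In a functional assay on HeLa cells (Homo sapiens) for antiproliferative activity, with a stated time of 24 h (a higher number here means a weaker inhibitor, a lower number a stronger inhibitor), compound 1 gives 26700 nM. Compound 2 `Cc1ccccc1NC(=S)N1CCc2c(sc(NC(=O)c3ccccc3Cl)c2C(N)=O)C1` reaches only a limit of the assay in this assay, > 50000 nM. Compound 3 gives 44000 nM in this assay, within the scatter of compound 1. The difference between the cores of compound 1 and compound 3 is not broken down here.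

The change methyl in place of trifluoromethyl on an aromatic carbon gave an at least 1.8-fold higher number from compound 1 to compound 2 (0.27 log units; that floor lies within the scatter), its floor set by the limit of > 50000 nM in this assay, at which 1 of the 3 values shown sits. Compound 4 `Cc1ccc(C(=O)Nc2sc3c(c2C(N)=O)CCN(C(=S)Nc2ccccc2Cl)C3)cc1` arises from compound 3 by methyl in place of trifluoromethyl on an aromatic carbon; the place differs, ortho to a large group before and para to a large group here, so this is the same kind of change, not the same.

From compound 3 a step of a 1.6-fold higher number from compound 3 to compound 4 (0.20 log units; within the scatter) is expected, resting on compound 3 at 44000 nM and on the earlier step. The estimate for compound 4 is 70000 nM, likely only a limit.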

Compound 4, half-maximal inhibitory concentration: 26300 nM
Compound 4: the middle estimate sits 2.7-fold (0.43 log units) above what was measured; the measured number lies below the stated range.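

In this assay, methyl in place of trifluoromethyl gave a 1.7-fold lower number from compound 3 to compound 4 (0.22 log units; within the scatter). Carried from one core to another in this series, the change does not give one transferable step: the same change on two cores in this assay, an at least 1.8-fold higher number (0.27 log units; that floor lies within the scatter) from compound 1 to compound 2 and a 1.7-fold lower number (0.22 log units; within the scatter) from compound 3 to compound 4, at least 3.1-fold (0.49 log units) apart, beyond the scatter of two such steps. Going by these compounds alone, with only two pairs, which differ both in core and in the place on the ring, this does not show which of the two sets the gap apart, and compound 2 stands at a limit of the assay, not a number: the limit of > 50000 nM in this assay, at which 1 of the 4 values shown sits.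

From the compounds shown here alone, it remains open whether the two steps would agree with the change made at one place on one core. Also open, going by these compounds, is how an amine, a carboxylic acid or a longer chain would compare with methyl and trifluoromethyl there.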